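The compounds below may be only part of what the source reports. "The series", "measured", "known", "first", "only" and "open" are said of these compounds alone.

Working notes on the series, three compounds measured in an assay on isolated protein for antagonist activity at Bile acid receptor (Homo sapiens), read by TR-FRET, with a stated time of 20 min (a lower number here means a stronger inhibitor, a higher number a weaker inhibitor), so far. Compound 1 `Cc1ccc(-c2nn(-c3ccc(F)cc3)cc2C(=O)Nc2ccc(C)c(S(=O)(=O)N3CCOCC3)c2)cc1` gives 24.3 nM. Compound 2 `Cc1ccc(-c2nn(C(C)C)cc2C(=O)Nc2ccc(C)c(S(=O)(=O)N3CCOCC3)c2)cc1` gives 49.1 nM. Compound 3 `Cc1ccc(-c2nn(CCCCO)cc2C(=O)Nc2ccc(C)c(S(=O)(=O)N3CCOCC3)c2)cc1` gives 130 nM. The three differ only in the group on the aromatic nitrogen of the shared core: a 2.0-fold higher number from compound 1 to compound 2 (0.31 log units; beyond the scatter), a 5.3-fold higher number from compound 1 to compound 3 (0.73 log units; beyond the scatter), a 2.6-fold higher number from compound 2 to compound 3 (0.42 log units; beyond the scatter). Compound 2 therefore stands second highest of the three numbers, nearer to compound 1 than to compound 3, with both of its steps beyond the scatter.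

Compound 4 `COc1cccc(-c2nn(C(C)C)cc2C(=O)Nc2ccc(C)c(S(=O)(=O)N3CCOCC3)c2)c1` is not yet measured. It keeps the isopropyl of compound 2 and changes the other aryl group: 3-methoxyphenyl in place of 4-methylphenyl on an aromatic carbon. Among the measured compounds shown here, none of the measured steps touches this position; all three vary the group on the aromatic nitrogen, so they give no direct guide to the effect of exchanging 4-methylphenyl for 3-methoxyphenyl. For the measured compounds named here, with no precedent for this change, the expectation is a step of no more than the scatter, in no particular direction: a 1.1-fold higher number from compound 2 to compound 4 (0.05 log units; within the scatter) is expected. Compound 4 is estimated at 55 nM in this assay, within a range of 20 nM to 150 nM.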

Compound 4, half-maximal inhibitory concentration: 160 nM
Estimate against measurement, compound 4: 2.9-fold (0.46 log units) below; measured number outside the range, above it.
By their numbers in this assay, from the lowest: compound 1; then compound 2; then compounds 3 and 4 (each within the scatter of the next).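

In this assay the position on the aromatic carbon proves responsive: 3-methoxyphenyl in place of 4-methylphenyl gives a 3.3-fold higher number from compound 2 to compound 4 (0.51 log units; beyond the scatter) and so makes this compound a weaker inhibitor. Among the compounds shown here, the earlier compounds all kept 4-methylphenyl here and varied only the group on the aromatic nitrogen, so this is the first sign that the aryl group on carbon also affects the number. With the isopropyl group held constant across the pair, the step belongs to this one exchange, but nothing measured on these compounds explains it.

The exchange changes both the substituent and where it sits on the phenyl ring, and the compounds shown cannot separate the two; 4-methoxyphenyl and 3-methylphenyl at the same position would divide the step between them. On these data alone, it also remains open whether the same exchange has a similar effect when the aromatic nitrogen carries 4-fluorophenyl or 4-hydroxybutyl instead of isopropyl.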